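From carboxymethoxy to isopropoxy: the solubility of compound 3

The compounds below may be only part of what the source reports. "The series", "measured", "known", "first", "only" and "open" are said of these compounds alone.

Compound 1 (`COCCn1cc(C(=O)C(=O)Nc2ccc(OCC(=O)O)nc2)c2ccccc21`) has been measured in a physicochemical assay for solubility, in phosphate buffer, at pH 7.4; a higher number here means a more soluble compound, a lower number a less soluble compound. There compound 1 gives <= 200000 nM, which is a limit and not a number. Compound 2 (`COc1ccc(NC(=O)C(=O)c2cc(C(C)C)n3ccccc23)cn1`) gives a numerical reading of 10000 nM in this assay. Compound 3 (`COCCn1cc(C(=O)C(=O)Nc2ccc(OC(C)C)nc2)c2ccccc21`) keeps the core of compound 1 but has isopropyl in place of carboxymethyl on an oxygen on an aromatic ring. Going by the values given here, no measured pair of compounds shows what this change does, so the expectation rests on compound 2 , which also has no carboxymethyl group and gives 10000 nM. A fall well beyond the usual scatter is expected in this assay, with an estimated size of a step that the limit leaves unreadable from compound 1 to compound 3. For compound 3 the expected value is 5000 nM, with an estimated range of 1000 nM to 25000 nM.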

Compound 3, solubility: 10000 nM
Compound 3: middle estimate off by 2.0-fold (0.30 log units), on the low side; measured number inside the range.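

No size can be read for the step from compound 1 to compound 3 in this assay: compound 1 gives <= 200000 nM, which is a limit and not a number. The compounds shown leave open what isopropyl in place of carboxymethyl on an oxygen on an aromatic ring does in this assay.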